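Adding 4-methylpiperazin-1-yl to the amidine aryl of compound 1

The source may hold more compounds than are shown below. What is called first, only, known or untested is meant among the compounds shown, and "the series" means these compounds.

Measured compounds:
compound 1 `COc1ccc(Cn2nc(-c3ccccc3)c3cc(C(=N)Nc4ccccc4)nc(NC4CCCCC4)c32)cc1` 3400 nM
compound 2 `N=C(Nc1ccccc1)c1cc2c(-c3ccccc3)n[nH]c2c(NC2CCCCC2)n1` 850 nM

In a functional assay on HT-1080 cells (Homo sapiens) for cytotoxicity, read by MTT assay, with a stated time of 72 h (on this read-out lower numbers stand for stronger inhibition and higher numbers for weaker inhibition), compound 1 gives 3400 nM, the highest of the two numbers at hand; its nearest neighbour is compound 2, which in this assay gives 850 nM, reached by a 4.0-fold lower number from compound 1 to compound 2 (0.60 log units; beyond the scatter). That single step concerns hydrogen in place of 4-methoxybenzyl on an aromatic nitrogen and does not touch the aryl amidine. Compound 3 `COc1ccc(Cn2nc(-c3ccccc3)c3cc(C(=N)Nc4ccc(N5CCN(C)CC5)cc4)nc(NC4CCCCC4)c32)cc1` differs from compound 1 only there: 4-methylpiperazin-1-yl in place of hydrogen on an aromatic carbon. Within the data shown here, no measured step speaks to a substituent at this place, so nothing in the data supports a change in either direction; the expectation is a step within the scatter. In this assay compound 3 is therefore estimated at 3000 nM (range 800 nM to 10000 nM), which would mean a 1.1-fold lower number from compound 1 to compound 3 (0.05 log units; within the scatter), an expected step of no size beyond the scatter.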

Compound 3, half-maximal inhibitory concentration: 640 nM
Estimate against measurement, compound 3: 4.7-fold (0.67 log units) above; the whole stated range lies above it.
By their numbers in this assay, from the lowest: compounds 3 and 2 (each within the scatter of the next); then compound 1.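

In this assay, the aryl of the amidine turns out to be a place that responds: 4-methylpiperazin-1-yl in place of hydrogen on an aromatic carbon gives a 5.3-fold lower number from compound 1 to compound 3 (0.73 log units; beyond the scatter). Among these compounds, the only earlier step, a 4.0-fold lower number from compound 1 to compound 2 (0.60 log units; beyond the scatter), lay on the aromatic nitrogen, so this is the first sign that the amidine aryl also bears on the number, and the change works with the 4-methoxybenzyl still in place. Nothing measured on these compounds speaks to the origin of this step.

From the compounds shown here alone, it remains open whether the whole 4-methylpiperazin-1-yl is needed, or whether a smaller dimethylamino group or a morpholin-4-yl ring at the same place would do the same. Going by these compounds, it is also open whether this step would add to the one on the aromatic nitrogen.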